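Same Side-Chain Swap on a Second Core

The compounds below may be only part of what the source reports. "The series", "measured", "known", "first", "only" and "open" are said of these compounds alone.

Measured in a functional assay on a cell-free system (Platelet, plasma, Homo sapiens) for inhibition; a higher number here means a weaker inhibitor, a lower number a stronger inhibitor:
Compound 1 `CC(CC(=O)O)N1Cc2ccc(NC(=O)c3ccc4c(c3)CNCC4)cc2C1=O` gives 86 nM.
Compound 2 `O=C(O)CCCN1Cc2ccc(NC(=O)c3ccc4c(c3)CNCC4)cc2C1=O` gives 330000 nM.
Compound 3 `O=C(O)CCCN1Cc2ccc(NC(=O)c3ccc(C4CCNCC4)cc3)cc2C1=O` gives 410000 nM.

Compound 2 and compound 3 give numbers within the scatter of each other; the difference between their two cores is not broken down here. Compound 4 `CC(CC(=O)O)N1Cc2ccc(NC(=O)c3ccc(C4CCNCC4)cc3)cc2C1=O` has not yet been measured in this assay. It differs from compound 3 by 1-(carboxymethyl)ethyl in place of 3-carboxypropyl on an amide-type nitrogen in a ring, at the same place, word for word, as the change from compound 2 to compound 1, (1-(carboxymethyl)ethyl in place of 3-carboxypropyl on an amide-type nitrogen in a ring), which brought a 3800-fold lower number from compound 2 to compound 1 (3.58 log units; beyond the scatter). For the measured compounds named here, the step is expected to be of similar size, a 2700-fold lower number from compound 3 to compound 4 (3.44 log units; beyond the scatter), because it rests on the single earlier step of a 3800-fold lower number from compound 2 to compound 1 (3.58 log units; beyond the scatter) seen on a closely related core. Since that step was seen only once, the range is kept wide. Compound 4 is expected to give about 150 nM, with a likely range from 20 nM to 3000 nM.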

Compound 4, half-maximal inhibitory concentration: 6200 nM
Beside the measured number, compound 4's estimate is 41-fold (1.62 log units) below it; measured number above the stated range.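

Putting 1-(carboxymethyl)ethyl in place of 3-carboxypropyl again gives a stronger inhibitor on the second core, with a 66-fold lower number from compound 3 to compound 4 (1.82 log units; beyond the scatter), so the direction of the change carries over. The size of the change does not carry over, and the two steps differ by more than scatter can account for: the same change on two cores in this assay, a 3800-fold lower number (3.58 log units; beyond the scatter) from compound 2 to compound 1 and a 66-fold lower number (1.82 log units; beyond the scatter) from compound 3 to compound 4, 58-fold (1.76 log units) apart, beyond the scatter of two such steps. For the compounds shown here, with only two cores, this shows that the size of the gain cannot simply be copied from one core to another, but it does not show which part of the core matters or what a third core would give.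

Going by these compounds, whether a shorter chain, such as carboxymethyl, on the same amide-type nitrogen would show the same core-to-core difference remains open. So does the outcome of replacing the carboxylic acid with an ester on either core.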